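The source may report more compounds than this note shows. Statements on the series, on what has been measured and on what is new or still open speak of the compounds shown alone.

For the measured compounds named here, compound 1 `N=C(N)c1ccc(-c2ccc(-c3ccc(Cl)cc3)o2)o1` is one of two compounds measured in a functional assay on K562 cells (Homo sapiens) for inhibition, read by sulforhodamine B assay, with a stated time of 48 h (on this read-out higher numbers stand for weaker inhibition of growth and lower numbers for stronger inhibition of growth), where compound 1 gives 1370 nM. Its companion, compound 2 `N=C(N)c1ccc(-c2ccc(-c3ccc4ccccc4c3)s2)s1`, gives in this assay 1530 nM; the gap between the two numbers lies within the scatter, so the two compounds cannot be told apart on this read-out, although compound 1 carries the lower of the two numbers. Compound 3 `N=C(N)c1ccc(-c2ccc(-c3ccccc3)o2)o1` has not yet been measured. It differs from compound 1 in one place: hydrogen in place of chloro on an aromatic carbon of a six-membered aromatic ring of carbon only. Going by the values given here, no step between measured compounds matches this change, so there is no measured guide to its size. A modest weakening is expected, with the step of a 1.8-fold higher number from compound 1 to compound 3 (0.26 log units; within the scatter) lying somewhat beyond the scatter. For compound 3 the expected number in this assay is 2500 nM, within 1000 nM and 6500 nM.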

Compound 3, concentration for 50% growth inhibition: 660 nM
Beside the measured number, compound 3's estimate is 3.8-fold (0.58 log units) above it, and the stated range ends above it.
By their numbers in this assay, from the lowest: compound 3; then compounds 1 and 2 (each within the scatter of the next).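

In this assay, hydrogen in place of chloro on an aromatic carbon, para to a large group, gives a 2.1-fold lower number from compound 1 to compound 3 (0.32 log units; beyond the scatter). For the compounds shown here, this is the first step that changes a single place, and it shows that the chloro group at this position is not needed for growth inhibition in these cells, since the compound carrying hydrogen there has the lower number. Nothing available bears on why the step runs in this direction.

On these data alone, with only chloro and hydrogen compared at this position, it remains open how a fluoro, methoxy or amine group there would compare with either. As far as these compounds go, it also remains open whether the same change would give a step of similar size on a different core.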